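This account rests on a few compounds, and the source may have more. Where it says the series, first, only, none or still open, it means among the compounds named here.

Working notes on the series. In a functional assay on A549 cells (Homo sapiens) for inhibition, read by MTT assay, with a stated time of 48 h (on this read-out lower numbers stand for stronger inhibition and higher numbers for weaker inhibition), compound 1 (`COc1ccc(N(C)c2nc(C)nc3ccccc23)cc1[Se]C`) gives 11 nM and compound 2 (`CN(c1ccc([Se]C#N)cc1)c1nc(C2CC2)nc2ccccc12`) gives 12 nM with the two inside the scatter of each other, so together they form the low end of the numbers in hand. Compound 3 (`COc1ccc(N(C)c2nc(C)nc3ccccc23)cc1C(=O)OCCCCC[Se]C#N`) gives 592 nM at the high end, beyond the scatter from compound 1.

The next compound to read is compound 4 (`COc1ccc(N(C)c2nc(C)nc3ccccc23)cc1OCCCCC[Se]C#N`), which shares the core of compound 1. The structural change is a group of 9 heavy atoms (6 carbon, 1 nitrogen, 1 oxygen, 1 selenium; no ring) in place of a group of 2 heavy atoms (1 carbon, 1 selenium; no ring), on an aromatic carbon on an aromatic carbon of a six-membered aromatic ring of carbon only, ortho to a methoxy group. For the measured compounds named here, no step between measured compounds is available as a guide. Going by the values given here, the closest reference is compound 3 at 592 nM as the one measured compound on this core with a long chain ending in a nitrile. Compound 2 at 12 nM also ends in a nitrile without such a chain, so among these three that ending alone does not go with a high number. A rise beyond the scatter is expected, with the estimate being an 18-fold higher number from compound 1 to compound 4 (1.26 log units; beyond the scatter) in the direction of weaker inhibition. In this assay compound 4 is estimated at 200 nM with an expected range from 40 nM to 900 nM for the coming measurement.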

Compound 4, half-maximal inhibitory concentration: 2440 nM
Beside the measured number, compound 4's estimate is 12-fold (1.09 log units) below it; the whole stated range lies below it.
By their numbers in this assay, from the lowest: compounds 1 and 2 (each within the scatter of the next); then compound 3; then compound 4.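

For the compounds shown here, on the aromatic carbon ortho to a methoxy group, the shared core does not keep its low number in this assay when the group of 9 heavy atoms replaces the group of 2 heavy atoms, with a 220-fold higher number from compound 1 to compound 4 (2.35 log units; beyond the scatter) as the first step that can be read at this position. Among the long chains ending in a nitrile at this position, the attachment also goes with a difference in the printed values: compound 3, with its chain held through an ester carbonyl, gives 592 nM, and compound 4, with its chain held through an ether oxygen, gives 2440 nM. Nothing in hand explains the size of this rise or the order of these two compounds.

The compounds shown do not separate the contributions of chain length, selenium and the nitrile ending, so a shorter chain on the same ether oxygen or the same chain ending in a methyl group on selenium would be the informative comparison. Also open, as far as these compounds go, is how the position responds to a chain ending in an amine or a carboxylic acid.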